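The compounds below may be only part of what the source reports. "The series", "measured", "known", "first", "only" and "open" are said of these compounds alone.

Of the compounds shown here, three have so far been measured in an in vitro ADME assay on microsomes from liver (Homo sapiens) for metabolic stability; a higher number here means faster removal of the compound, a lower number slower removal. Compound 1 `Fc1ccccc1Cc1nc(-c2nc(C(F)(F)F)n[nH]2)c2ccccn12` gives 20 mL.min-1.g-1. Compound 2 `Cc1ncc(Cc2nc(-c3nc(C(F)(F)F)n[nH]3)n3ccccc23)cn1` gives < 8 mL.min-1.g-1, which is a limit of the assay rather than a number. Compound 3 `Cc1n[nH]c(-c2nc(Cc3ccccc3F)c3ccccn23)n1` gives 124 mL.min-1.g-1, the higher of the two numbers and beyond the scatter from compound 1. Compound 4 `NC(=O)c1n[nH]c(-c2nc(Cc3ccccc3F)c3ccccn23)n1` has not been measured; it differs from compound 3 in one place: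

carbamoyl in place of methyl on an aromatic carbon

Among the measured compounds shown here, no step between measured compounds that differ in one place is available, so the size of this change rests on expectation alone. Compound 4 is expected to show a lower number, a step of a 3.1-fold lower number from compound 3 to compound 4 (0.49 log units; beyond the scatter) in this assay. Compound 4 is therefore estimated at 40 mL.min-1.g-1, within 12 mL.min-1.g-1 to 110 mL.min-1.g-1.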

Compound 4, intrinsic clearance in microsomes: < 8 mL.min-1.g-1
Compound 4 gave a limit, no number; the forecaster's own chance of this, stated with the estimate: 10%; at least 5.0-fold (0.69 log units) between middle value and limit.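

In this assay, the first step measured at this position is large: going from 3-methyl-1H-1,2,4-triazol-5-yl to 3-carbamoyl-1H-1,2,4-triazol-5-yl gives an at least 15-fold lower number from compound 3 to compound 4 (1.19 log units; beyond the scatter). A single change on this aromatic carbon, with the rest of the molecule the same, is therefore enough to move the number well beyond the scatter. The full size of the step remains unknown, because compound 4 gave a limit rather than a number: the limit of < 8 mL.min-1.g-1 in this assay, at which 2 of the 4 values shown sit.

From the compounds shown here alone, whether a nitrile, an amine or a carboxylic acid on this carbon would give a similar drop remains open.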